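Swapping 2-fluorophenyl for 3-aminophenyl on the shared core

This account rests on a few compounds, and the source may have more. Where it says the series, first, only, none or still open, it means among the compounds named here.

- compound 1 `COc1cc(C(=O)c2cn(-c3ccc(N)cc3)cc2-c2ccccc2)cc(OC)c1OC` at 35 nM
- compound 2 `COc1cc(C(=O)c2cn(-c3cccc(C)c3)cc2-c2cccc(N)c2)cc(OC)c1OC` at 130 nM
- compound 3 `COc1cc(C(=O)c2cn(-c3ccc(N)cc3)cc2-c2ccccc2F)cc(OC)c1OC` at 28 nM

In a functional assay on MCF7 cells (Homo sapiens) for cytotoxicity, read by MTT assay, with a stated time of 96 h (on this read-out lower numbers stand for stronger inhibition and higher numbers for weaker inhibition), compound 3 at 28 nM sits within the scatter of compound 1 at 35 nM and well under compound 2 at 130 nM on these numbers.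

The next case is compound 4 `COc1cc(C(=O)c2cn(-c3ccc(N)cc3)cc2-c2cccc(N)c2)cc(OC)c1OC` with 3-aminophenyl in place of 2-fluorophenyl on an aromatic carbon and the 4-aminophenyl group kept. Going by the values given here, the one measured step at this place (a 1.3-fold lower number from compound 1 to compound 3 (0.10 log units; within the scatter)) is fluoro in place of hydrogen and stays within the scatter. Among the compounds with values here, no measured step isolates 3-aminophenyl. Compound 2 carries that group at 130 nM but lacks the 4-aminophenyl group, so it points only loosely towards a higher number.

A small rise is therefore expected (a 1.8-fold higher number from compound 3 to compound 4 (0.25 log units; within the scatter)) and it may not clear the scatter. Compound 4 is estimated at 50 nM with an expected range from 18 nM to 130 nM until it is measured.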

Compound 4, half-maximal inhibitory concentration: 78 nM
The estimate for compound 4 lay 1.6-fold (0.19 log units) below the measured number; the measured number falls inside the stated range.
By their numbers in this assay, from the lowest: compounds 3 and 1 (each within the scatter of the next); then compounds 4 and 2 (each within the scatter of the next).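

In this assay, this position gives its first step beyond the scatter: amino in place of hydrogen on the aromatic carbon moves the number modestly (a 2.2-fold higher number from compound 1 to compound 4 (0.35 log units; beyond the scatter)), whereas fluoro in place of hydrogen stayed within the scatter (a 1.3-fold lower number from compound 1 to compound 3 (0.10 log units; within the scatter)). The direct exchange of 2-fluorophenyl for 3-aminophenyl, with the 4-aminophenyl group kept, is also modest and beyond the scatter (a 2.8-fold higher number from compound 3 to compound 4 (0.44 log units; beyond the scatter)). With 3-aminophenyl held, 4-aminophenyl in place of 3-methylphenyl on the aromatic nitrogen stays within the scatter (a 1.7-fold lower number from compound 2 to compound 4 (0.22 log units; within the scatter)), so this pair does not separate those two groups.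

From the compounds shown here alone, whether a hydroxyl or methoxy group on this phenyl would read like fluoro or like amino remains open. Nothing available here accounts for the rise seen with 3-aminophenyl.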